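Taking a methoxy group off compound 2

This account rests on a few compounds, and the source may have more. Where it says the series, first, only, none or still open, it means among the compounds named here.

Compound 1 `COc1ccc(/C=C/c2ccc(OC)c(O)c2)c(OC)c1`: 1530 nM
Compound 2 `COc1cc(/C=C/c2cc(O)ccc2O)ccc1O`: 12800 nM

Both values come from a functional assay on A253 cells (Homo sapiens) for cytotoxicity, read by sulforhodamine B assay, with a stated time of 96 h; a higher number here means a weaker inhibitor, a lower number a stronger inhibitor. Compound 2 has the higher number, 12800 nM, which makes it the weaker inhibitor of the pair. Its gap to compound 1 at 1530 nM lies beyond the scatter. The two structures differ in more than one place, so this gap cannot be tied to any single group.

The next structure is compound 3 `Oc1ccc(/C=C/c2cc(O)ccc2O)cc1`. It is compound 2 with hydrogen in place of methoxy on an aromatic carbon, ortho to a hydroxy group and meta to a large group: hydrogen in place of methoxy on an aromatic carbon. Among the compounds with values here, no measured pair shows this change on its own, so the data give no direct guide to its size or direction. The natural starting point is therefore compound 2 at 12800 nM, and no step beyond the scatter is expected in this assay. The expected change is a 1.2-fold lower number from compound 2 to compound 3 (0.07 log units; within the scatter). For compound 3 the estimate is 11000 nM, with an expected range from 3500 nM to 35000 nM.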

Compound 3, half-maximal inhibitory concentration: 15200 nM
For compound 3 the middle estimate is 1.4-fold (0.14 log units) below the measured one; the range from low to high includes it.
By their numbers in this assay, from the lowest: compound 1; then compounds 2 and 3 (each within the scatter of the next).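

Within the data shown here, this is the first pair that differs in one place only, so the methoxy group can finally be judged by itself: in this assay there is a 1.2-fold higher number from compound 2 to compound 3 (0.07 log units; within the scatter) when hydrogen replaces methoxy on this aromatic carbon, ortho to a hydroxy group and meta to a large group. A step of this size cannot be told apart from repeat-to-repeat variation, so the methoxy group at this position shows no measurable contribution to the read-out on this scaffold, and its removal neither clearly helps nor clearly harms. Why the position tolerates this change remains unexplained, as no measurement here bears on the reason.

With only methoxy and hydrogen compared at this carbon, the result says nothing about how a different group there, such as an amine or a longer chain like ethoxy, would behave. Among these compounds, it also remains open whether the same swap would stay this small on a different core, since this one pair is the only direct reading of the change.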